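Lengthening a nitroimidazole tether: expected effect on growth inhibition

This account rests on a few compounds, and the source may have more. Where it says the series, first, only, none or still open, it means among the compounds named here.

Compound 1 `COc1cc2c(Nc3ccc(OCc4cccc(F)c4)c(Cl)c3)ncnc2cc1OCCCCCn1ccnc1[N+](=O)[O-]`: 14400 nM
Compound 2 `COc1cc2c(Nc3ccc(OCc4cccc(F)c4)c(Cl)c3)ncnc2cc1OCCCCCCn1ccnc1[N+](=O)[O-]`: > 50000 nM
Compound 3 `COc1cc2c(Nc3cccc(Br)c3)ncnc2cc1OCCCCn1ccnc1[N+](=O)[O-]`: 1970 nM

Three compounds were measured in a functional assay on A549 cells (Homo sapiens) for inhibition, read by sulforhodamine B assay, with a stated time of 72 h; a lower number here means a stronger inhibitor, a higher number a weaker inhibitor. Compound 1 gives 14400 nM. For compound 2 the assay reports only a limit, > 50000 nM. For the measured compounds named here, the difference between compound 1 and compound 2 is (2-nitro-1H-imidazol-1-yl)methyl in place of 2-nitro-1H-imidazol-1-yl on a saturated chain carbon, five bonds along the chain from an oxygen on an aromatic ring, and it brought an at least 3.4-fold higher number from compound 1 to compound 2 (0.54 log units; beyond the scatter); the only evidence bearing on that step is the limit of > 50000 nM in this assay, at which 1 of the 3 values shown sits. Compound 3 gives 1970 nM, the lower of the two numbers reported; how its core differs from that of compound 1 is not broken down here.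

Compound 4 `COc1cc2c(Nc3cccc(Br)c3)ncnc2cc1OCCCCCn1ccnc1[N+](=O)[O-]` has not been measured in this assay. It differs from compound 3 by (2-nitro-1H-imidazol-1-yl)methyl in place of 2-nitro-1H-imidazol-1-yl on a saturated chain carbon, four bonds along the chain from an oxygen on an aromatic ring. Going by the values given here, this is the same kind of change as the one between compound 1 and compound 2, but the place differs: in compound 3 the chain carbon is four bonds along the chain from an oxygen on an aromatic ring, in compound 1 five bonds. Because an at least 3.4-fold higher number from compound 1 to compound 2 (0.54 log units; beyond the scatter) was seen for the same kind of change, a weaker number is expected. Compound 4 is therefore expected to show a step of a 3.0-fold higher number from compound 3 to compound 4 (0.48 log units; beyond the scatter). The estimate for compound 4 in this assay is 6000 nM, expected to fall between 2500 nM and 20000 nM.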

Compound 4, half-maximal inhibitory concentration: 8420 nM
The estimate for compound 4 lay 1.4-fold (0.15 log units) below the measured number; the range from low to high includes it.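

In this assay, putting (2-nitro-1H-imidazol-1-yl)methyl in place of 2-nitro-1H-imidazol-1-yl on the bromine-bearing core gave a 4.3-fold higher number from compound 3 to compound 4 (0.63 log units; beyond the scatter), and the number moved the same way on both cores: the same change on two cores in this assay, an at least 3.4-fold higher number (0.54 log units; beyond the scatter) from compound 1 to compound 2 and a 4.3-fold higher number (0.63 log units; beyond the scatter) from compound 3 to compound 4; the limit leaves it open whether they differ The step on the core of compound 1 rests on a value that is only a limit: the limit of > 50000 nM in this assay, at which 1 of the 4 values shown sits. These two pairs therefore show that the direction of the change carried over from one core to the other, but they do not fix the size of the step on the core of compound 1, and two cores cannot show that the trend holds across the whole series.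

The compounds shown leave open whether a longer chain on the core of compound 3, such as one ending in 3-(2-nitro-1H-imidazol-1-yl)propyl, would keep raising the number. Also open, as far as these compounds go, is how a tether ending in an amine in place of 2-nitro-1H-imidazol-1-yl would read in this assay.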